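Swapping the Trifluoromethylphenyl Group for Fluorophenyl on Piperazine

The source may report more compounds than this note shows. Statements on the series, on what has been measured and on what is new or still open speak of the compounds shown alone.

Three measured compounds share one core and differ only in the chain and in the aryl group on the piperazine nitrogen. In an assay on HEK293 cells for inhibition of Voltage-dependent T-type calcium channel subunit alpha-1G (Homo sapiens), read by fluorescence, tested at 10 uM (a higher number here means more inhibition at the concentration tested (going by the name of the read-out), a lower number less inhibition), compound 1 `CCCc1nc(-c2ccccc2)c(CNCCN2CCN(c3cccc(C(F)(F)F)c3)CC2)o1` gives 56.3%. Compound 2 `CCCc1nc(-c2ccccc2)c(CNCCCN2CCN(c3cccc(C(F)(F)F)c3)CC2)o1` gives 51.6% and compound 3 `CCCc1nc(-c2ccccc2)c(CNCCCN2CCN(c3cccc(F)c3)CC2)o1` gives 68.9%. Compound 1 thus stands second of the three, within the scatter of compound 2 and beyond the scatter below compound 3. Compound 4 `CCCc1nc(-c2ccccc2)c(CNCCN2CCN(c3ccc(F)cc3)CC2)o1` is compound 1 with 4-fluorophenyl in place of 3-(trifluoromethyl)phenyl on an amine nitrogen in a ring. Among the compounds with values here, the one measured step that bears on this is a number 17.3 percentage points higher from compound 2 to compound 3 (beyond the scatter), where fluoro also replaced trifluoromethyl, though compound 2 and compound 3 carry a longer chain between the two amine nitrogens and compound 3 carries fluoro rather than 4-fluorophenyl. A modest rise is therefore expected, a number 9.7 percentage points higher from compound 1 to compound 4 (within the scatter). Compound 4 is estimated at 66%, within 50% to 80%.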

Compound 4, a percentage reported as inhibition, at one concentration (the size of the read-out at that concentration, not a potency): 54.1%
Estimate against measurement, compound 4: 11.9 percentage points above; low and high end bracket the measured number.
By their numbers in this assay, from the lowest: compounds 2, 4 and 1 (each within the scatter of the next); then compound 3.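

In this assay, 4-fluorophenyl in place of 3-(trifluoromethyl)phenyl on the amine nitrogen in the ring gives a number 2.2 percentage points lower from compound 1 to compound 4 (within the scatter), so this change on the chain of compound 1 leaves no clear mark on the read-out. The rise of a number 17.3 percentage points higher from compound 2 to compound 3 (beyond the scatter) does not recur here, yet that pair differs from this one both in its longer chain and in where the fluoro sits. Nothing measured here explains why the two steps differ. Still open, on these data alone, is whether the chain or the place of the fluoro separates the two steps, and how a methoxy group or a chlorine in place of the fluoro would read in this assay.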